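The source may hold more compounds than are shown below. What is called first, only, known or untested is meant among the compounds shown, and "the series" means these compounds.

Measured in a functional assay on Right cardiac atrium for agonist activity at histamine H2 receptor (Cavia porcellus), with a stated time of 30 min, in the presence of a further agent that is not named here; on this read-out lower numbers stand for an effect already at smaller amounts and higher numbers for an effect only at larger amounts of compound:
compound 1 `Cc1nc(N)sc1CCCN/C(N)=N/C(=O)N[C@H](C)c1ccccc1`: 7.59 nM
compound 2 `Cc1nc(N)sc1CCCN/C(N)=N/C(=O)N[C@@H](C)c1ccccc1`: 23.4 nM
compound 3 `CCCCCCNC(=O)/N=C(\N)NCCCc1sc(N)nc1C`: 15.9 nM

Compound 3 stands second highest of the three numbers. Against compound 2 it lies within the scatter, a 1.5-fold lower number from compound 2 to compound 3 (0.17 log units; within the scatter); against compound 1 the step is a 2.1-fold higher number from compound 1 to compound 3 (0.32 log units; beyond the scatter). Between compounds 1 and 2 the change rests on the fact that compounds 1 and 2 differ only in the configuration as drawn and gives a 3.1-fold higher number from compound 1 to compound 2 (0.49 log units; beyond the scatter).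

Compound 4 `CCCCCNC(=O)/N=C(\N)NCCCc1sc(N)nc1C` differs from compound 3 by hydrogen in place of methyl on a saturated chain carbon, five bonds along the chain from an amide-type nitrogen. Within the data shown here, no measured step shortens this chain. Among the measured compounds shown here, the only steps touching the same amide-type nitrogen, a 2.1-fold higher number from compound 1 to compound 3 (0.32 log units; beyond the scatter) and a 1.5-fold lower number from compound 2 to compound 3 (0.17 log units; within the scatter), exchanged the whole group and stayed modest; loss of one methyl is a smaller change. No step beyond the scatter is therefore expected. Compound 4 is estimated at 20 nM with a range of 8 nM to 50 nM. This expected value amounts to a step of a 1.3-fold higher number from compound 3 to compound 4 (0.10 log units; within the scatter).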

Compound 4, half-maximal effective concentration: 5.75 nM
Compound 4: middle estimate off by 3.5-fold (0.54 log units), on the high side; the whole stated range lies above it.
By their numbers in this assay, from the lowest: compounds 4 and 1 (each within the scatter of the next); then compounds 3 and 2 (each within the scatter of the next).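

In this assay, hydrogen in place of methyl on a saturated chain carbon, five bonds along the chain from an amide-type nitrogen, is a step beyond the scatter even though only one carbon leaves: a 2.8-fold lower number from compound 3 to compound 4 (0.44 log units; beyond the scatter). Pentyl in place of 1-phenylethyl reads differently for the two drawn configurations: a 4.1-fold lower number from compound 2 to compound 4 (0.61 log units; beyond the scatter), against a 1.3-fold lower number from compound 1 to compound 4 (0.12 log units; within the scatter). Nothing measured here gives a cause for the chain step.

The compounds shown leave open whether a butyl or a heptyl chain on this nitrogen would continue or reverse the step seen with pentyl and hexyl.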